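A few compounds are considered here, and "the series" means these few. Any claim that something is new, unique, unknown or untested is made for them only; others in the source may bear on it.

Measured so far in an ADME assay on microsomes from liver (Mus musculus) for metabolic stability, read by LC-MS, using NADPH; on this read-out higher numbers stand for a longer-lived compound and lower numbers for a shorter-lived compound:
compound 1 `CCC(C)(C)C(=O)N(O)Cc1ccc(F)c(F)c1F` gives 0.232 h
compound 2 `CCC(C)(C)C(=O)N(O)Cc1ccc(F)cc1F` gives 0.387 h
compound 3 `CCC(C)(C)C(=O)N(O)Cc1cc(F)c(F)c(F)c1` gives 0.132 h

Compound 2 stands level, within the scatter, with compound 1, while compound 3 shows a lower number than compound 2 by a margin beyond the scatter. The next step leads to compound 4 `CCC(C)(C)C(=O)N(O)Cc1ccc(F)cc1`, which has hydrogen in place of fluoro on an aromatic carbon. This carbon is ortho to a large group and meta to a fluoro group. Among the measured compounds shown here, one measured step bears on this change: a 1.7-fold higher number from compound 1 to compound 2 (0.22 log units; within the scatter) is the same swap on another aromatic carbon, and it stays within the scatter. A single step is thin ground, so only a small rise or no change beyond the scatter is expected. The expected move is a 1.2-fold higher number from compound 2 to compound 4 (0.07 log units; within the scatter) in this assay and no more. The estimate for compound 4 is 0.45 h in this assay, with an expected range from 0.22 h to 0.85 h around that middle.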

Compound 4, half-life: 0.402 h
For compound 4 the middle estimate is 1.1-fold (0.05 log units) above the measured one; the measured number falls inside the stated range.
By their numbers in this assay, from the lowest: compounds 3, 1, 2 and 4 (each within the scatter of the next, the first and the last beyond it).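

In this assay, the change on the aromatic carbon ortho to a large group and meta to a fluoro group gives a 1.0-fold higher number from compound 2 to compound 4 (0.02 log units; within the scatter) and so does not separate fluoro from hydrogen at this position. Together with a 1.7-fold higher number from compound 1 to compound 2 (0.22 log units; within the scatter) on another aromatic carbon, this makes two such swaps in the series, and neither moves the half-life beyond the scatter. Nothing measured here gives a reason for this flat result.

As far as these compounds go, whether a methoxy group, a chloro group or an amine on this same carbon would move the half-life remains open, as does the effect of replacing the remaining fluoro group of compound 4 with hydrogen or a nitrile. Compound 3, at 0.132 h, differs from the other compounds in more than one place, so its lower number cannot be tied to any single position.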